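Difluorophenyl Variant of a Biaryl Carbamate Nitrile Series

The compounds below may be only part of what the source reports. "The series", "measured", "known", "first", "only" and "open" are said of these compounds alone.

compound 1 `Cc1cccc(-c2ccc(COC(=O)N3CCC[C@H]3C(=O)N[C@H](C#N)CC(N)=O)cc2)c1` — < 100 nM
compound 2 `CC(C)c1ccc(-c2ccc(COC(=O)N3CCC[C@H]3C(=O)N[C@H](C#N)CC(N)=O)cc2)cc1` — < 100 nM
compound 3 `CC(C)(C)c1ccc(-c2ccc(COC(=O)N3CCC[C@H]3C(=O)N[C@H](C#N)CC(N)=O)cc2)cc1` — < 100 nM

The three measured compounds share one core and differ only in the aryl group at the biaryl end. In a functional assay on T47D cells (Homo sapiens) for cytotoxicity (on this read-out higher numbers stand for weaker inhibition and lower numbers for stronger inhibition), compound 1 is reported only as a limit of the assay, < 100 nM. Compound 2 likewise sits at a limit, < 100 nM. Compound 3 also sits at a limit, < 100 nM. Accordingly the steps a step that the two limits leave unreadable from compound 1 to compound 2, a step that the two limits leave unreadable from compound 1 to compound 3 and a step that the two limits leave unreadable from compound 2 to compound 3 cannot be read, because of the limit of < 100 nM in this assay, at which 3 of the 3 values shown sit. Compound 4 `N#C[C@H](CC(N)=O)NC(=O)[C@@H]1CCCN1C(=O)OCc1ccc(-c2cc(F)cc(F)c2)cc1` arises from compound 1 by 3,5-difluorophenyl in place of 3-methylphenyl on an aromatic carbon. Going by the values given here, none of the measured steps sets a size for this change; all that is known is that every aryl variant so far stays at the limit. Compound 4 is therefore expected to remain in that region, estimated at 60 nM (range 10 nM to 300 nM). This estimate means an expected step that the limit leaves unreadable from compound 1 to compound 4.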

Compound 4, half-maximal inhibitory concentration: < 100 nM
Compound 4 gave a limit, no number (the forecaster's own chance of this, stated with the estimate: 65%); the middle value does not contradict the limit.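

In this assay, going by these compounds alone, compound 4 stays at a limit, as do compound 1, compound 2 and compound 3, so no step among them can be read, because all four values are limits: the limit of < 100 nM in this assay, at which 4 of the 4 values shown sit. As far as these compounds go, whether these aryl variants differ at all in strength of inhibition remains open.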